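This account rests on a few compounds, and the source may have more. Where it says the series, first, only, none or still open, it means among the compounds named here.

Of the compounds shown here, two sharing one core have been measured. Compound 1 `Cc1ccnc([C@@H](C)Oc2cc3oc(=O)n(CCC(=O)O)c3cc2Cl)c1` gives 3.98 nM in an assay for inhibition of kynurenine 3-monooxygenase (Homo sapiens), read by mass spectrometry, with a stated time of 1 h; a higher number here means a weaker inhibitor, a lower number a stronger inhibitor. Among the compounds with values here, compound 2 `C[C@@H](Oc1cc2oc(=O)n(CCC(=O)O)c2cc1Cl)c1ccc(Cl)cn1` gives 3.16 nM in this assay, the lowest of the two numbers, with compound 1 nearest; the one step, a 1.3-fold lower number from compound 1 to compound 2 (0.10 log units; within the scatter), exchanged one pyridinyl group for another at the saturated chain carbon bound to the oxygen and lay within the scatter. Compound 3 `C[C@@H](Oc1cc2oc(=O)n(CCC(=O)O)c2cc1Cl)c1ccc(F)cn1` is not yet measured. It differs from compound 2 by fluoro in place of chloro on an aromatic carbon, which reads 5-chloropyridin-2-yl to 5-fluoropyridin-2-yl when cut one bond further out. Within the data shown here, no measured step exchanges one halogen for another at this place; the only step available, from compound 1 to compound 2, shows that a change at the pyridinyl group left the number within the scatter. Compound 3 is therefore expected to sit close to compound 2, with an expected step of a 1.4-fold higher number from compound 2 to compound 3 (0.15 log units; within the scatter) and an estimated 4.5 nM in this assay, in the range 2 nM to 10 nM.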

Compound 3, half-maximal inhibitory concentration in the kynurenine 3-monooxygenase assay: 2.51 nM
Compound 3: middle estimate off by 1.8-fold (0.25 log units), on the high side; the range from low to high includes it.
By their numbers in the kynurenine 3-monooxygenase assay, from the lowest: compounds 3, 2 and 1 (each within the scatter of the next).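

In the kynurenine 3-monooxygenase assay, fluoro in place of chloro on the aromatic carbon gives a 1.3-fold lower number from compound 2 to compound 3 (0.10 log units; within the scatter), and the exchange of the whole pyridinyl group gives a 1.6-fold lower number from compound 1 to compound 3 (0.20 log units; within the scatter), so this position has so far tolerated all three groups without a step beyond the scatter. Within the data shown here, in a physicochemical assay for lipophilicity, read by HPLC, at pH 7.4 (on this read-out lower numbers stand for lower lipophilicity and higher numbers for higher lipophilicity), however, compound 2 gives 2.65 and compound 3 gives 1.98, which shows for the first time that a change at this position can separate the compounds. Fluoro in place of chloro at this place thus lowers lipophilicity while the inhibition numbers stay within the scatter of each other: the measured distribution coefficient of compound 2, 2.65, and of compound 3, 1.98, a number 0.67 log units lower (beyond the scatter)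

The compounds shown leave open how a nitrile or a methoxy group at this place would read in the kynurenine 3-monooxygenase assay and the physicochemical assay.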